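Hydroxy in place of hydrogen: estimate for compound 3

A few compounds are considered here, and "the series" means these few. Any claim that something is new, unique, unknown or untested is made for them only; others in the source may bear on it.

Measured so far:
Compound 1 `N=C(N)c1cccc(CN2CC[C@H](NS(=O)(=O)c3ccc(-c4ccccn4)s3)C2=O)c1` reaches only a limit of > 2100 nM in an assay on isolated protein for inhibition of Trypsin II (Bos taurus); a lower number here means a stronger inhibitor, a higher number a weaker inhibitor.
Compound 2 `N=C(N)c1cccc(CN2CC[C@H](NS(=O)(=O)c3ccc(-c4ccon4)s3)C2=O)c1` gives 1900 nM in this assay.

Going by the values given here, compound 2 thus holds the only number in this assay; the other value shown is a limit (the limit of > 2100 nM in this assay, at which 1 of the 2 values shown sits). Among the compounds with values here, the single measured step, an at least 1.1-fold lower number from compound 1 to compound 2 (0.04 log units; that floor lies within the scatter), concerns a different aromatic carbon and does not bear on the change to compound 3 `N=C(N)c1ccc(O)c(CN2CC[C@H](NS(=O)(=O)c3ccc(-c4ccon4)s3)C2=O)c1`, which is hydroxy in place of hydrogen on an aromatic carbon. Within the data shown here, with no measured step touching this position, the expected step of a 1.3-fold lower number from compound 2 to compound 3 (0.10 log units; within the scatter) is none beyond the scatter. Compound 3 is therefore estimated at 1500 nM, between 400 nM and 6000 nM.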

Compound 3, inhibition constant: 2900 nM
For compound 3 the middle estimate is 1.9-fold (0.29 log units) below the measured one, and the stated range covers the measured number.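

Hydroxy in place of hydrogen, ortho to a large group and para to a group of 3 heavy atoms, is the first measured change on this six-membered aromatic ring of carbon only. In this assay it gives a 1.5-fold higher number from compound 2 to compound 3 (0.18 log units; within the scatter), so this position takes a hydroxy group with no step beyond the scatter. Nothing measured here bears on this result.

Open, as far as these compounds go, are other groups at this position, such as methoxy, an amine or a carboxylic acid. Also open, from the compounds shown here alone, is how hydroxy reads alongside the pyridin-2-yl of compound 1, whose value is only a limit.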